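Extending a Methyl to an Ethyl on Compound 3

The source may report more compounds than this note shows. Statements on the series, on what has been measured and on what is new or still open speak of the compounds shown alone.

In an ADME assay on microsomes from liver (Rattus norvegicus) for metabolic stability (a higher number here means faster removal of the compound, a lower number slower removal), compound 1 (`Cc1ccc(NC(=O)c2cc(Oc3ccc(S(C)(=O)=O)cc3)cc(OC(C)C)c2)nc1`) gives 97 mL/min/kg while compound 2 (`CC(C)Oc1cc(Oc2ccc(S(C)(=O)=O)cc2)cc(-c2nccc(=O)[nH]2)c1`) gives 105 mL/min/kg and compound 3 (`Cc1cnc(-c2cc(Oc3ccc(S(C)(=O)=O)cc3)cc(OC(C)C)c2)[nH]c1=O`) with 189 mL/min/kg lies within the scatter of both. Compound 4 (`CCc1cnc(-c2cc(Oc3ccc(S(C)(=O)=O)cc3)cc(OC(C)C)c2)[nH]c1=O`) differs from compound 3 by methyl in place of hydrogen on a saturated chain carbon bound to an aromatic carbon in a swap of methyl to ethyl, that is, methyl in place of hydrogen on a saturated chain carbon bound to an aromatic carbon. The closest measured change is the step of a 1.8-fold higher number from compound 2 to compound 3 (0.26 log units; within the scatter) for methyl in place of hydrogen on an aromatic carbon, and that step stays within the scatter. On that evidence, the expected step of a 1.0-fold higher number from compound 3 to compound 4 (0.00 log units; within the scatter) is none beyond the scatter. Compound 4 is estimated at 190 mL/min/kg with an expected range from 105 mL/min/kg to 340 mL/min/kg in this measurement.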

Compound 4, clearance: 171 mL/min/kg
For compound 4 the middle estimate is 1.1-fold (0.05 log units) above the measured one; low and high end bracket the measured number.
By their numbers in this assay, from the lowest: compounds 1, 2, 4 and 3 (each within the scatter of the next).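

In this assay, ethyl in place of methyl at this position gives a 1.1-fold lower number from compound 3 to compound 4 (0.04 log units; within the scatter), so one further carbon on the chain makes no difference that can be told from the scatter. Ethyl in place of hydrogen gives a 1.6-fold higher number from compound 2 to compound 4 (0.21 log units; within the scatter), and the group of compound 4 in place of the larger group of compound 1 gives a 1.8-fold higher number from compound 1 to compound 4 (0.25 log units; within the scatter), so these steps also stay within the scatter. Nothing measured here bears on why these steps are so small.

On these data alone, whether a longer chain such as propyl, an amine or a carboxylic acid at this position would move clearance beyond the scatter remains open.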